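The source may hold more compounds than are shown below. What is called first, only, known or untested is meant among the compounds shown, and "the series" means these compounds.

Series notes on a functional assay on the whole organism (plasma, strain albino) for inhibition, with Rattus norvegicus as the target, with stated times of 1 h and 4 h, at a dose of 50 mg/kg by the oral route; on this read-out higher numbers stand for a stronger effect at the one dose given and lower numbers for a weaker effect. Three compounds are measured. Compound 1 `COc1ccc(Cl)cc1C(=O)Nc1ccc(C(=O)/C=C/c2ccccc2[N+](=O)[O-])cc1` gives 80.4%. Compound 2 `COc1ccc(C2CC(c3ccc(NC(=O)c4cc(Cl)ccc4OC)cc3)=NN2C)cc1` gives 81.8% in this assay. Compound 3 `COc1ccc(C2CC(c3ccc(NC(=O)c4cc(Cl)ccc4OC)cc3)=NN2c2ccccc2)cc1` gives 90.2% in this assay, the highest of the three numbers, with compound 2 nearest and compound 1 furthest, both gaps within the scatter, so no order among the three is established. Going by the values given here, the one step between compounds that differ in a single place is a number 8.4 percentage points higher from compound 2 to compound 3 (within the scatter), a change on an amine nitrogen in a ring that leaves the number where it was.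

Compound 4 `COc1ccc(Cl)cc1C(=O)Nc1ccc(C2=NN(c3ccccc3)C(c3ccc([N+](=O)[O-])cc3)C2)cc1` is not yet measured. It differs from compound 3 by nitro in place of methoxy on an aromatic carbon. Among the compounds with values here, no measured step replaces a methoxy with a nitro, so none of the steps bears on this change directly; the only measured step, a number 8.4 percentage points higher from compound 2 to compound 3 (within the scatter), touches another part of the structure. Compound 1 carries a nitro group and gives 80.4%, but on a different core, so only the two values can be set side by side. With nothing pointing either way, no step beyond the scatter is expected in this assay. The expected step is a number 5.2 percentage points lower from compound 3 to compound 4 (within the scatter). Compound 4 is estimated at 85%, between 70% and 95%.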

Compound 4, a percentage reported as inhibition, in the whole organism at one dose (the size of the read-out at that dose, not a potency): 85.3%
Estimate against measurement, compound 4: 0.3 percentage points below; measured number inside the range.
By their numbers in this assay, from the lowest: compounds 1, 2, 4 and 3 (each within the scatter of the next).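

In this assay the change from 4-methoxyphenyl to 4-nitrophenyl, on an aromatic carbon para to a large group, gives a number 4.9 percentage points lower from compound 3 to compound 4 (within the scatter), so this exchange at this position moves the number by no more than repeated measurements would. Going by these compounds alone, the earlier compounds varied only the amine nitrogen in a ring, so this is the first reading at this position, and it places a nitro group on the shared core rather than only on the different core of compound 1. Nothing measured here explains the size of this step or links it to any property of methoxy or nitro.

A single exchange at one dose cannot show whether the position is generally insensitive in this assay, and an amine or a carboxylic acid in the same place would test this with a group unlike either methoxy or nitro. Going by these compounds, it also remains open whether the same exchange gives a similar result with methyl in place of phenyl on the amine nitrogen in the ring.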